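Working notes: from compound 1 to compound 4

The source may hold more compounds than are shown below. What is called first, only, known or untested is meant among the compounds shown, and "the series" means these compounds.

Measured so far in an ADME assay on BHK cells (Mesocricetus auratus) for cytotoxicity, read by MTT assay, with a stated time of 96 h; a higher number here means that more compound is tolerated, a lower number that less compound is tolerated:
- compound 1 `Oc1ccc(-c2nc3cc(C(F)(F)F)ccc3[nH]2)cc1`: > 100000 nM (a limit, not a number)
- compound 2 `COc1ccc(-c2nc3cc(C(F)(F)F)ccc3[nH]2)c(OC)c1`: > 100000 nM (a limit, not a number)
- compound 3 `COc1cc(-c2nc3cc(C(F)(F)F)ccc3[nH]2)cc(OC)c1OC`: 31000 nM

Compound 1 stands at the limit of > 100000 nM in this assay, at which 2 of the 3 values shown sit. Its true position is therefore not known, and it offers no exact starting point for a step.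

Compound 3 is the only one of the three with a numerical reading, at 31000 nM.

The next compound to be read is compound 4 `O=[N+]([O-])c1ccc(-c2nc3cc(C(F)(F)F)ccc3[nH]2)cc1`. It differs from compound 1 in one place, with nitro in place of hydroxy on an aromatic carbon, para to a large group (nitro in place of hydroxy on an aromatic carbon). Among the compounds with values here, no pair of measured compounds in this set differs in one place, so the series gives no direct measure of what such a change does.

A modest step is expected in this assay, in the direction of less compound tolerated: an at least 1.6-fold lower number from compound 1 to compound 4 (0.22 log units; that floor lies within the scatter). This expectation rests loosely on compound 3, whose 31000 nM shows that a number can be obtained within this series. A reading at the limit also remains a real possibility for compound 4.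

Compound 4 is estimated at 60000 nM, with an expected range from 20000 nM to 100000 nM.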

Compound 4, half-maximal cytotoxic concentration: 18000 nM
Beside the measured number, compound 4's estimate is 3.3-fold (0.52 log units) above it; measured number below the stated range.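

Replacing hydroxy with nitro on an aromatic carbon, para to a large group, gives in this assay an at least 5.5-fold lower number from compound 1 to compound 4 (0.74 log units; beyond the scatter). Within the data shown here, this is the first pair that differs in one place, and it shows that a change at this one position is enough to give compound 4 a numerical reading of 18000 nM. The step is only a floor and its true size remains unknown, because compound 1 stands at a limit and not at a number: the limit of > 100000 nM in this assay, at which 2 of the 4 values shown sit.

Among these compounds, the single pair cannot separate what the loss of hydroxy contributes from what the entry of nitro contributes, and it gives no way to tell whether the lower number follows nitro specifically or would appear with other replacements, such as an amine or a carboxylic acid in the same place. It also leaves open whether the same exchange would produce a step of similar size on a different aromatic carbon, or on a core that differs from that of compound 1.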